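This account rests on a few compounds, and the source may have more. Where it says the series, first, only, none or still open, it means among the compounds named here.

The study concerns four esters built on a shared core. Compound 1 `CCOC(=O)c1c(-c2cccc(Cl)c2)[nH]c2cc(OC)ccc2c1=O` carries a chlorine on the pendant ring, and compound 2 `CCOC(=O)c1c(-c2cccc(Br)c2)[nH]c2cc(OC)ccc2c1=O` differs from it by bromo in place of chloro on an aromatic carbon. Compound 3 `CCOC(=O)c1c(-c2cccc(Cl)c2)[nH]c2cc(OC)c(F)cc2c1=O` is compound 1 with fluoro in place of hydrogen on an aromatic carbon, and compound 4 `CCOC(=O)c1c(-c2cccc(Br)c2)[nH]c2cc(OC)c(F)cc2c1=O` is the still unmeasured partner of compound 3, differing from it by bromo in place of chloro on an aromatic carbon, which is the same change as that from compound 1 to compound 2, now made on the core of compound 3.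

In an ADME assay on Raji cells (Homo sapiens) for cytotoxicity, read by luminescence, with a stated time of 72 h (on this read-out lower numbers stand for an effect already at smaller amounts and higher numbers for an effect only at larger amounts of compound), compound 1 reaches only a limit, > 21500 nM. In this assay compound 2 likewise reaches only a limit, > 21500 nM. In this assay compound 3 also stays at a limit, > 21500 nM. Accordingly a step that the two limits leave unreadable from compound 1 to compound 2 and a step that the two limits leave unreadable from compound 1 to compound 3, because of the limit of > 21500 nM in this assay, at which 3 of the 3 values shown sit.

For compound 4 the expected step in this assay is a step that the limit leaves unreadable from compound 3 to compound 4, and this expectation rests on compound 1 because a step that the two limits leave unreadable from compound 1 to compound 2. Compound 4 is therefore expected to show no numeric value in this assay, with an estimate of 30000 nM spanning 15000 nM to 100000 nM.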

Compound 4, half-maximal effective concentration: > 21500 nM
Compound 4 was reported as a limit; the forecaster's own chance of this, stated with the estimate: 85%; the middle value does not contradict the limit.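

In this assay compound 4 also reaches only a limit (> 21500 nM). No step can be read from compound 3 to compound 4 or from compound 2 to compound 4, because all the values rest on one limit: (the limit of > 21500 nM in this assay, at which 4 of the 4 values shown sit). The compounds shown leave open how large any effect of bromo in place of chloro, or of fluoro in place of hydrogen, would be in this assay on the shared core.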